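This account rests on a few compounds, and the source may have more. Where it says the series, first, only, none or still open, it means among the compounds named here.

Of the compounds shown here, three built on one shared core have been tested in a functional assay on NCI-H460 cells (Homo sapiens) for cytotoxicity, read by MTT assay, with a stated time of 72 h; a higher number here means a weaker inhibitor, a lower number a stronger inhibitor. Compound 1 `CN(C)CCn1cnnc1-c1cc(Oc2ccc(NC(=O)N/N=C/c3ccc(O)c(Br)c3)cc2F)ccn1` gives 430 nM in this assay. Compound 2 `CN(C)CCn1cnnc1-c1cc(Oc2ccc(NC(=O)N/N=C/c3ccccc3O[N+](=O)[O-])cc2F)ccn1` gives 1270 nM, and compound 3 `CN(C)CCn1cnnc1-c1cc(Oc2ccc(NC(=O)N/N=C/c3ccc(F)cc3F)cc2F)ccn1` gives 1930 nM. Compound 1 thus stands lowest of the three numbers, meaning it is the strongest inhibitor of this small set.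

Compound 4 `CN(C)CCn1cnnc1-c1cc(Oc2ccc(NC(=O)N/N=C/c3cccc(O)c3)cc2F)ccn1` has not yet been measured. It differs from compound 1 in a single place: 3-hydroxyphenyl in place of 3-bromo-4-hydroxyphenyl on a carbon with a double bond to nitrogen. Among the measured compounds shown here, two measured steps bear directly on this change, since each of them also exchanges the 3-bromo-4-hydroxyphenyl of compound 1 for a different aromatic group on the same carbon. Both steps raised the number: a 3.0-fold higher number from compound 1 to compound 2 (0.47 log units; beyond the scatter) and a 4.5-fold higher number from compound 1 to compound 3 (0.65 log units; beyond the scatter). The step of a 1.5-fold higher number from compound 2 to compound 3 (0.18 log units; within the scatter) between those two replacements lies within the scatter, so the size of the rise has been similar whatever group entered. A modest rise is therefore expected for compound 4 as well, though the 3-hydroxyphenyl retains a hydroxyl group, which the groups in compound 2 and compound 3 do not, so a somewhat smaller rise is expected, a 2.0-fold higher number from compound 1 to compound 4 (0.30 log units; within the scatter). Compound 4 is expected to give about 850 nM in this assay, within a range from 350 nM to 2100 nM.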

Compound 4, half-maximal inhibitory concentration: 780 nM
Compound 4: middle estimate off by 1.1-fold (0.04 log units), on the high side, within the range that was stated.
By their numbers in this assay, from the lowest: compounds 1, 4, 2 and 3 (each within the scatter of the next, the first and the last beyond it).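

The change from 3-bromo-4-hydroxyphenyl to 3-hydroxyphenyl on the carbon with a double bond to nitrogen gives, in this assay, a 1.8-fold higher number from compound 1 to compound 4 (0.26 log units; within the scatter), so this is the first replacement shown that stays within the scatter of compound 1, and a bromine is not needed for that. The other comparisons give a mixed picture: 3-hydroxyphenyl in place of 2,4-difluorophenyl gives a 2.5-fold lower number from compound 3 to compound 4 (0.39 log units; beyond the scatter), which is beyond the scatter, whereas 3-hydroxyphenyl in place of 2-(nitrooxy)phenyl gives a 1.6-fold lower number from compound 2 to compound 4 (0.21 log units; within the scatter), which is within it, so compound 2 goes against any simple rule that a group with a hydroxyl sets itself apart from one without. No measurement is available to explain these differences.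

The compounds shown leave open how much the bromine and the hydroxyl each contribute, since the two groups differ in both, and 3-bromophenyl, 4-hydroxyphenyl and plain phenyl groups would help separate those contributions. Going by these compounds, it also remains open whether an amine or a carboxylic acid in place of the hydroxyl on this ring would keep the number close to that of compound 1.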